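The source may hold more compounds than are shown below. What is called first, only, known or untested is meant among the compounds shown, and "the series" means these compounds.

Notes on the series sharing the core of compound 1 `O=C(Nc1ccccc1)Nc1cccc(CNc2nccnc2Cl)c1`. In a functional assay on T-24 cells (Homo sapiens) for antiproliferative activity, read by MTT assay, with a stated time of 48 h (a higher number here means a weaker inhibitor, a lower number a stronger inhibitor), compound 1 gives 19800 nM. Compound 2 `Cc1ccc(NC(=O)Nc2cccc(CNc3nccnc3Cl)c2)cc1Cl` gives 7390 nM and compound 3 `O=C(Nc1cccc(CNc2nccnc2Cl)c1)Nc1ccccc1F` gives 7450 nM. The steps read a 2.7-fold lower number from compound 1 to compound 2 (0.43 log units; beyond the scatter) and a 2.7-fold lower number from compound 1 to compound 3 (0.42 log units; beyond the scatter), while a 1.0-fold higher number from compound 2 to compound 3 (0.00 log units; within the scatter). Compound 2 thus holds the lowest of the three numbers, though its gap to compound 3 is within the scatter. Compound 4 `COc1ccccc1NC(=O)Nc1cccc(CNc2nccnc2Cl)c1` is not yet measured; it differs from compound 2 by 2-methoxyphenyl in place of 3-chloro-4-methylphenyl on an amide-type nitrogen. Among the compounds with values here, the one step that bears on this, an exchange of the group on the amide-type nitrogen, is a 1.0-fold higher number from compound 2 to compound 3 (0.00 log units; within the scatter), and it was flat; a further exchange at the same place is therefore expected to move this assay by no step beyond the scatter. Compound 4 is expected at 8000 nM, within 4000 nM to 16000 nM, which is a 1.1-fold higher number from compound 2 to compound 4 (0.03 log units; within the scatter).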

Compound 4, half-maximal inhibitory concentration: 10400 nM
The estimate for compound 4 lay 1.3-fold (0.11 log units) below the measured number, and the stated range covers the measured number.
By their numbers in this assay, from the lowest: compounds 2, 3, 4 and 1 (each within the scatter of the next, the first and the last beyond it).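

In this assay the exchange on the amide-type nitrogen stays flat again, with a 1.4-fold higher number from compound 2 to compound 4 (0.15 log units; within the scatter) and with a 1.4-fold higher number from compound 3 to compound 4 (0.14 log units; within the scatter) for methoxy in place of fluoro on an aromatic carbon. New is that a 1.9-fold lower number from compound 1 to compound 4 (0.28 log units; within the scatter) also lies within the scatter, whereas the steps from compound 1 to compounds 2 and 3 lie beyond it, so compound 4 separates from neither end of the series. Nothing measured here accounts for these readings.

Open, from the compounds shown here alone, is whether a pyridine, a saturated ring or a longer alkyl chain on the amide-type nitrogen would give a step beyond the scatter. Also open, going by these compounds, is how an amine or a carboxylic acid on the phenyl ring would read.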